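From phenyl to 4-chlorophenyl: working notes

This account rests on a few compounds, and the source may have more. Where it says the series, first, only, none or still open, it means among the compounds named here.

- compound 1 `CC1(C)[C@H]2CC[C@]1(C)N(Cc1cn(-c3cccc(C#N)c3)nn1)C(=O)C2` gives 250 nM in a functional assay on SGC-7901 cells (Homo sapiens) for inhibition, read by MTT assay, with a stated time of 24 h; on this read-out higher numbers stand for weaker inhibition and lower numbers for stronger inhibition
- compound 2 `CC1(C)[C@H]2CC[C@]1(C)N(Cc1cn(-c3ccccc3F)nn1)C(=O)C2` gives 300 nM in this assay
- compound 3 `CC1(C)[C@H]2CC[C@]1(C)N(Cc1cn(-c3ccccc3)nn1)C(=O)C2` gives 240 nM in this assay

The three numbers lie within the scatter of one another, so compound 3 at 240 nM cannot be set apart from either of the others. Compound 4 `CC1(C)[C@H]2CC[C@]1(C)N(Cc1cn(-c3ccc(Cl)cc3)nn1)C(=O)C2` is the next to be read. It differs from compound 3 by chloro in place of hydrogen on an aromatic carbon and in words this is chloro in place of hydrogen on an aromatic carbon, para to a large group.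

Among the measured compounds shown here, two measured steps bear on this change, as both swap hydrogen for a substituent on an aromatic carbon. One is a 1.0-fold lower number from compound 1 to compound 3 (0.02 log units; within the scatter) and the other is a 1.3-fold lower number from compound 2 to compound 3 (0.10 log units; within the scatter). For the measured compounds named here, neither involves chloro, and the data hold no chloro compound for direct comparison. Both steps stay within the scatter, so no shift in either direction is expected from this single change. The expected size is a 1.0-fold higher number from compound 3 to compound 4 (0.02 log units; within the scatter) in this assay and thus no step beyond the scatter. On these data alone, for compound 4 the estimated value is 250 nM with an expected range from 120 nM to 500 nM in this assay and this range is kept wide since chloro is untested here.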

Compound 4, half-maximal inhibitory concentration: 410 nM
Estimate against measurement, compound 4: 1.6-fold (0.21 log units) below; the range from low to high includes it.
By their numbers in this assay, from the lowest: compounds 3, 1, 2 and 4 (each within the scatter of the next).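

In this assay, among the compounds shown here, compound 4 is the first of the series with a substituent on an aromatic carbon para to a large group, and chloro in place of hydrogen there gives a step that stays within the scatter (a 1.7-fold higher number from compound 3 to compound 4 (0.23 log units; within the scatter)). The comparisons of the whole aryl group agree, with 4-chlorophenyl in place of 2-fluorophenyl (a 1.4-fold higher number from compound 2 to compound 4 (0.14 log units; within the scatter)) and in place of 3-cyanophenyl (a 1.6-fold higher number from compound 1 to compound 4 (0.21 log units; within the scatter)) also within the scatter, so this position carries chloro without a readable difference, and the four compounds cannot be separated on this read-out. Nothing at hand gives a measured basis for interpreting these small steps.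

Still open, on these data alone, is whether a group of another kind at the same place, such as an amine, a carboxylic acid or a methoxy group, would give a step beyond the scatter. Also open is whether a longer chain on the aromatic nitrogen in place of the aryl group would leave the number as flat as the aryl groups shown here do.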